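This account rests on a few compounds, and the source may have more. Where it says the series, first, only, none or still open, it means among the compounds named here.

Measured in a physicochemical assay for solubility, at pH 7.4; a lower number here means a less soluble compound, a higher number a more soluble compound:

- compound 1 `CC[C@H]1[C@@H](N)CN1c1c(F)cc2c(=O)c(C(=O)O)cn(C3CC3)c2c1F`: 55.9 ug/mL
- compound 2 `CNC1(C)CN(c2cc3c(cc2F)c(=O)c(C(=O)O)cn3C2CC2)C1`: 0.7 ug/mL

Only these two compounds have been measured so far. Compound 2 stands lowest of the pair, and its gap to compound 1 lies well beyond the usual scatter of repeated measurements. The next compound to be measured is compound 3 `CNC1(C)CN(c2c(F)cc3c(=O)c(C(=O)O)cn(C4CC4)c3c2F)C1`, which differs from compound 2 in one place: fluoro in place of hydrogen on an aromatic carbon.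

For the measured compounds named here, no measured pair shows what this kind of swap does in this assay, so any forecast is uncertain. With compound 2 at 0.7 ug/mL, close to the bottom of what has been seen, a small rise seems more likely than a further fall, perhaps only just beyond the scatter. The expected change is a 2.9-fold higher number from compound 2 to compound 3 (0.46 log units; beyond the scatter). For compound 3 the estimated value is 2 ug/mL, with an expected range of 0.5 ug/mL to 10 ug/mL.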

Compound 3, solubility: 0.5 ug/mL
Estimate against measurement, compound 3: 4.0-fold (0.60 log units) above; measured number inside the range.
By their numbers in this assay, from the lowest: compounds 3 and 2 (each within the scatter of the next); then compound 1.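

In this assay, fluoro in place of hydrogen on this aromatic carbon, ortho to a 3-methyl-3-(methylamino)azetidin-1-yl group, gives a 1.4-fold lower number from compound 2 to compound 3 (0.15 log units; within the scatter), so this swap leaves the two compounds indistinguishable here. The exchange of one four-membered ring group for another on an aromatic carbon, with the same count of heavy atoms on each side, gives a 110-fold lower number from compound 1 to compound 3 (2.05 log units; beyond the scatter), a large step that shows the read-out can shift widely with the group at this one place. For the compounds shown here, nothing measured so far explains the size of either step.

Going by these compounds, it remains open whether a chloro or methoxy group on the same aromatic carbon would also stay within the scatter of compound 2. Also open is which part of the four-membered ring group goes with the large step, as the substituents on that ring differ together in the compounds shown.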